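This account rests on a few compounds, and the source may have more. Where it says the series, first, only, none or still open, it means among the compounds named here.

Three compounds built on one shared core were tested in a functional assay on MCF7 cells (Homo sapiens) for cytotoxicity, read by MTT assay, with a stated time of 24 h; on this read-out higher numbers stand for weaker inhibition and lower numbers for stronger inhibition. Compound 1 `Cc1ccc(-c2nnc(N3CCN(C(=O)CN4CCN(c5ccccc5Cl)CC4)CC3)nc2-c2ccc(C)cc2)cc1` gives 859000 nM, compound 2 `Cc1ccc(-c2nnc(N3CCN(C(=O)CN4CCN(c5cccc(Cl)c5)CC4)CC3)nc2-c2ccc(C)cc2)cc1` gives 797000 nM, and compound 3 `Cc1ccc(-c2nnc(N3CCN(C(=O)CN4CCN(c5ccc(Cl)cc5)CC4)CC3)nc2-c2ccc(C)cc2)cc1` gives 660000 nM. Changing where the chloro group sits made little difference: a 1.1-fold lower number from compound 1 to compound 2 (0.03 log units; within the scatter), a 1.3-fold lower number from compound 1 to compound 3 (0.11 log units; within the scatter) and a 1.2-fold lower number from compound 2 to compound 3 (0.08 log units; within the scatter), so compound 3 sits alongside the other two rather than apart from them. Compound 4 `Cc1ccc(-c2nnc(N3CCN(C(=O)CN4CCN(c5ccc([N+](=O)[O-])cc5)CC4)CC3)nc2-c2ccc(C)cc2)cc1` has not yet been measured; it differs from compound 3 by nitro in place of chloro on an aromatic carbon. Within the data shown here, none of the measured steps exchanges chloro for another group, so they offer no direct guide; they show only that small changes on this outer ring left the numbers in this assay unmoved. For compound 4 a step of a 1.1-fold higher number from compound 3 to compound 4 (0.03 log units; within the scatter) is therefore expected, and its number is estimated at 700000 nM, between 300000 nM and 1600000 nM.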

Compound 4, half-maximal inhibitory concentration: 845000 nM
The estimate for compound 4 lay 1.2-fold (0.08 log units) below the measured number, and the stated range covers the measured number.
By their numbers in this assay, from the lowest: compounds 3, 2, 4 and 1 (each within the scatter of the next).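

Among these compounds, this is the first exchange of chloro for a different kind of group, and nitro on the aromatic carbon, para to a large group, stays within the scatter (a 1.3-fold higher number from compound 3 to compound 4 (0.11 log units; within the scatter)). The 4-nitrophenyl compound also stays within the scatter of both other chloro compounds (a 1.1-fold higher number from compound 2 to compound 4 (0.03 log units; within the scatter); a 1.0-fold lower number from compound 1 to compound 4 (0.01 log units; within the scatter)). No measurement shown here accounts for this.

Going by these compounds, whether an amine or a carboxylic acid on this outer ring would shift the number remains open. So does the effect of any change to the shared core.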